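Fluoro for methoxy on the aryl urea of compound 1

A few compounds are considered here, and "the series" means these few. Any claim that something is new, unique, unknown or untested is made for them only; others in the source may bear on it.

For the measured compounds named here, compound 1 `COc1ccc(NC(=O)Nc2cc(C)nc3ccccc23)cc1` is the more permeable of the two measured members. In an ADME assay for permeability, using PAMPA, at pH 7.4 (a higher number here means that the compound crosses the layer faster, a lower number that the compound crosses the layer more slowly), compound 1 gives 787 10^-6 cm/s, while compound 2 `Cc1cc(NC(=O)Nc2cccc(C(N)=O)c2)c2ccccc2n1` gives 2 10^-6 cm/s in this assay, a gap far beyond the scatter. Going by the values given here, the two differ in more than one place, so no single step is drawn between them; the pair only marks the span covered so far.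

Compound 3 `Cc1cc(NC(=O)Nc2ccc(F)cc2)c2ccccc2n1` departs from compound 1 by one change: fluoro in place of methoxy on an aromatic carbon. Fluoro in place of methoxy on an aromatic carbon removes the one hydrogen-bond acceptor of that group and brings in none. With no measured step of this kind in the series, the expectation rests on compound 1 alone, whose reading in this assay is already among the high values of such measurements. The step from compound 1 to compound 3 is expected to be a 1.0-fold higher number from compound 1 to compound 3 (0.01 log units; within the scatter), within the scatter or slightly upward. Compound 3 is estimated at 800 10^-6 cm/s, with a range from 350 10^-6 cm/s to 1600 10^-6 cm/s.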

Compound 3, apparent permeability: 801 10^-6 cm/s
The estimate for compound 3 lay 1.0-fold (0.00 log units) below the measured number; the range from low to high includes it.
By their numbers in this assay, from the lowest: compound 2; then compounds 1 and 3 (each within the scatter of the next).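

At the aromatic carbon para to a large group, fluoro in place of methoxy gives a 1.0-fold higher number from compound 1 to compound 3 (0.01 log units; within the scatter) in this assay, the first single-place step read in this series. For this one pair, the high reading does not depend on keeping the hydrogen-bond acceptor of the methoxy, since the two values lie within the scatter of each other. No measurement at hand explains the size of this step.

From the compounds shown here alone, whether an amine, a carboxylic acid or a longer alkoxy chain at this position would also stay within the scatter of compound 1 remains open. Also open is which of the several differences between compound 1 and compound 2 accounts for the wide span between their values.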